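Replacing the hydroxymethylcyclopropyl group of compound 1

The compounds below may be only part of what the source reports. "The series", "measured", "known", "first", "only" and "open" are said of these compounds alone.

Compound 1 `CC(C)(C)c1ccccc1Oc1ncccc1NC(=O)Nc1ccc(C2(CO)CC2)cc1` gives 176 nM in an assay on isolated protein for binding affinity to P2Y purinoceptor 1 (Homo sapiens) (on this read-out higher numbers stand for weaker inhibition and lower numbers for stronger inhibition), the lower of the two numbers at hand. Compound 2 `CC(C)N1CCC(COc2ccc(NC(=O)Nc3cccnc3Oc3ccccc3C(C)(C)C)c(F)c2)CC1` gives 989 nM in this assay, a gap that lies beyond the usual scatter. Compound 3 `CC(C)CN1CCC(COc2ccc(NC(=O)Nc3cccnc3Oc3ccccc3C(C)(C)C)cc2)CC1` has not yet been measured; it differs from compound 1 in one place: (1-isobutylpiperidin-4-yl)methoxy in place of 1-(hydroxymethyl)cyclopropyl on an aromatic carbon. Among the measured compounds shown here, no measured pair shows this exact change, so the expectation rests on compound 2, whose related piperidinylmethoxy group goes with the weaker value 989 nM and points to a step toward weaker binding beyond the scatter. The estimate for compound 3 is 700 nM (from 250 nM to 2500 nM), an expected step of a 4.0-fold higher number from compound 1 to compound 3 (0.60 log units; beyond the scatter).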

Compound 3, inhibition constant: 87 nM
Estimate against measurement, compound 3: 8.0-fold (0.91 log units) above; the measured number lies below the stated range.
By their numbers in this assay, from the lowest: compound 3; then compound 1; then compound 2.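

At this place, on an aromatic carbon para to a large group, (1-isobutylpiperidin-4-yl)methoxy in place of 1-(hydroxymethyl)cyclopropyl strengthens binding modestly in this assay (a 2.0-fold lower number from compound 1 to compound 3 (0.31 log units; beyond the scatter)). For this pair, the hydrogen-bond donor of the leaving group is therefore not required, and the entering group, with more heavy atoms and a six-membered non-aromatic ring, does not weaken binding. Going by these compounds, what a free secondary amine or a morpholine would give at this place remains open. Nothing at hand explains the gain.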